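Cytotoxicity After a Fluorophenylethyl Swap on the Amine

The compounds below may be only part of what the source reports. "The series", "measured", "known", "first", "only" and "open" are said of these compounds alone.

Measured compounds:
compound 1 `CCc1ccc2[nH]c(=O)c(CN(Cc3ccc(O)cc3)Cc3ccc(C(C)(C)C)cc3)cc2c1` gives > 10000 nM
compound 2 `CCOc1ccc(CN(Cc2ccc(C(C)(C)C)cc2)Cc2cc3cc(C)ccc3[nH]c2=O)cc1` gives > 10000 nM
compound 3 `CCc1ccc2[nH]c(=O)c(CN(Cc3ccc(C(C)(C)C)cc3)C(C)c3ccc(F)cc3)cc2c1` gives 2800 nM

All three were tested in a toxicity assay on MDCK cells (Canis lupus familiaris) for cytotoxicity, read by crystal violet staining, with a stated time of 48 h; on this read-out higher numbers stand for lower toxicity in this test and lower numbers for higher toxicity in this test. For compound 2 the result is a limit of the assay, not a number: > 10000 nM. Compound 1 likewise sits at a limit, > 10000 nM. Compound 3 is the only one of the three with a numerical value, 2800 nM. Two of the three values therefore stand at the same boundary, as noted in the limit of > 10000 nM in this assay, at which 2 of the 3 values shown sit.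

The unmeasured compound 4 `Cc1ccc2[nH]c(=O)c(CN(Cc3ccc(C(C)(C)C)cc3)[C@H](C)c3ccc(F)cc3)cc2c1` differs from compound 2 in one place: 1-(4-fluorophenyl)ethyl in place of 4-ethoxybenzyl on an amine nitrogen. Going by the values given here, the closest measured step is the one from compound 1 to compound 3, where 1-(4-fluorophenyl)ethyl also entered on the amine nitrogen: an at least 3.5-fold lower number from compound 1 to compound 3 (0.55 log units; beyond the scatter). That step moved a limit into a measured number, with the 4-hydroxybenzyl leaving rather than the 4-ethoxybenzyl that leaves here.

On that basis compound 4 is expected to show a step of roughly the same size and direction, an at least 3.3-fold lower number from compound 2 to compound 4 (0.52 log units; beyond the scatter), in this assay. Compound 4 is therefore estimated at 3000 nM, with a range of 1000 nM to 10000 nM, close to the value of compound 3 and below the limit at which compound 2 stands.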

Compound 4, half-maximal cytotoxic concentration: > 5000 nM
Compound 4 gave a limit, no number; the forecaster's own chance of this, stated with the estimate: 25%; middle value at least 1.6-fold (0.22 log units) from the limit.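

In this assay compound 4 gives > 5000 nM, which is a limit and not a number. Compound 2 also stands at a limit, so the step between compound 2 and compound 4 cannot be read. The compounds shown leave open how far, if at all, 1-(4-fluorophenyl)ethyl in place of 4-ethoxybenzyl on an amine nitrogen moves this read-out.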